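What losing a side chain may do to compound 2

A few compounds are considered here, and "the series" means these few. Any claim that something is new, unique, unknown or untested is made for them only; others in the source may bear on it.

Values in a functional assay on HeLa cells (Homo sapiens) for inhibition, read by MTT assay, with a stated time of 72 h (a higher number here means a weaker inhibitor, a lower number a stronger inhibitor), for the measured compounds
- compound 1 `COc1cc(O)c(CC=C(C)C)c(O)c1C(=O)/C=C/c1ccc(O)c(O)c1` gives 38100 nM
- compound 2 `COc1ccccc1/C=C/C(=O)c1c(OC)cc(O)c(CC=C(C)C)c1O` gives 19700 nM
- compound 3 `COc1cc(O)c(CC=C(C)C)c(O)c1C(=O)/C=C/c1ccc([N+](=O)[O-])cc1` gives 29700 nM

Compound 2 cannot be told apart from the other two (a 1.9-fold lower number from compound 1 to compound 2 (0.29 log units; within the scatter)) and (a 1.5-fold higher number from compound 2 to compound 3 (0.18 log units; within the scatter)). Compound 4 `COc1ccccc1/C=C/C(=O)c1c(O)cc(O)cc1OC` carries hydrogen in place of 3-methylbut-2-en-1-yl on an aromatic carbon. The measured steps, including the third (a 1.3-fold lower number from compound 1 to compound 3 (0.11 log units; within the scatter)), change only the phenyl group on the double-bonded chain carbon, so none tests this loss directly. Any forecast is therefore cautious: starting from compound 2 (19700 nM), a modestly higher number is expected (a 1.8-fold higher number from compound 2 to compound 4 (0.25 log units; within the scatter)). For compound 4 the estimate is 35000 nM (expected range 14000 nM to 90000 nM).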

Compound 4, half-maximal inhibitory concentration: 43600 nM
Compound 4: middle estimate off by 1.2-fold (0.10 log units), on the low side; low and high end bracket the measured number.
By their numbers in this assay, from the lowest: compounds 2, 3, 1 and 4 (each within the scatter of the next, the first and the last beyond it).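

In this assay, within the data shown here, exchanging 3-methylbut-2-en-1-yl for hydrogen on this aromatic carbon gives a 2.2-fold higher number from compound 2 to compound 4 (0.35 log units; beyond the scatter) and is the only step here that goes beyond the usual scatter. So this position has a readable, though modest, effect on the number, which the phenyl changes among compounds 1, 2 and 3 did not show. No measurement at hand explains the shift. On these data alone, whether a longer chain or an amine on this carbon would keep the number near that of compound 2 stays open. So does whether the same loss would count alike in compound 1 and compound 3.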